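The source may report more compounds than this note shows. Statements on the series, on what has been measured and on what is new or still open speak of the compounds shown alone.

Measured compounds in an ADME assay on RAW264.7 cells (Mus musculus) for cytotoxicity, read by MTT assay, with a stated time of 48 h; on this read-out lower numbers stand for stronger inhibition and higher numbers for weaker inhibition:
Compound 1, `COc1cc(NC(=O)c2cccc(C(F)(F)F)c2)ccc1NS(C)(=O)=O`, gives 84800 nM.
Compound 2, `COc1cc(NC(=O)c2cccc(C(F)(F)F)c2)ccc1NS(=O)(=O)C(F)(F)F`, gives 75200 nM.
Compound 3, `COc1cc(NC(=O)c2cc(C(F)(F)F)cc(C(F)(F)F)c2)ccc1NS(=O)(=O)C(F)(F)F`, reaches only the assay's limit of > 250000 nM.

Compound 2 has the lowest of the two numbers shown, and its nearest neighbour is compound 1, with a 1.1-fold lower number from compound 1 to compound 2 (0.05 log units; within the scatter). Compound 4, `O=C(Nc1ccc(NS(=O)(=O)C(F)(F)F)c(Cl)c1)c1cccc(C(F)(F)F)c1`, differs from compound 2 by chloro in place of methoxy on an aromatic carbon. Neither measured step touches this position: a 1.1-fold lower number from compound 1 to compound 2 (0.05 log units; within the scatter) concerns the sulfonyl group, and an at least 3.3-fold higher number from compound 2 to compound 3 (0.52 log units; beyond the scatter) concerns the benzamide ring, the latter ending at the limit (the limit of > 250000 nM in this assay, at which 1 of the 3 values shown sits). Within the data shown here, no step therefore guides this change, and no step beyond the scatter is expected in this assay. Compound 4 is estimated at 80000 nM, within 35000 nM to 200000 nM, which means an expected 1.1-fold higher number from compound 2 to compound 4 (0.03 log units; within the scatter).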

Compound 4, half-maximal inhibitory concentration: 55800 nM
The estimate for compound 4 lay 1.4-fold (0.16 log units) above the measured number, and the stated range covers the measured number.
By their numbers in this assay, from the lowest: compounds 4, 2 and 1 (each within the scatter of the next). At a limit, above all of these: compound 3.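

In this assay, among these compounds, chloro in place of methoxy gives a 1.3-fold lower number from compound 2 to compound 4 (0.13 log units; within the scatter) at the aromatic carbon ortho to the ((trifluoromethyl)sulfonyl)amino group, a position the earlier steps did not touch. Compound 2 and compound 4 therefore stand level in this assay, so either group is accepted here without a step beyond the scatter. Nothing given here bears on a cause for this result.

From the compounds shown here alone, whether an amine, a hydroxyl group or a longer alkoxy chain at this position would also stay within the scatter remains open. So does whether chloro would behave alike alongside the second trifluoromethyl group of compound 3.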